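The source may hold more compounds than are shown below. What is called first, only, known or untested is meant among the compounds shown, and "the series" means these compounds.

Compound 1 `OCC(CO)OCn1c(Cl)nc2cc(Cl)c(Cl)cc21` is tested in a functional assay on KB cells (Homo sapiens) for inhibition; on this read-out higher numbers stand for weaker inhibition and lower numbers for stronger inhibition. Its reading is only a limit of that measurement: compound 1 gives > 100000 nM. Compound 2 `Nc1nc2cc(Cl)c(Cl)cc2n1COC(CO)CO` also gives only a limit, > 100000 nM. Compound 3 `OCC(CO)OCn1c(SCc2ccccc2)nc2cc(Cl)c(Cl)cc21` likewise gives only a limit, > 100000 nM. The steps a step that the two limits leave unreadable from compound 1 to compound 2, a step that the two limits leave unreadable from compound 1 to compound 3 and a step that the two limits leave unreadable from compound 2 to compound 3 therefore cannot be sized, since (the limit of > 100000 nM in this assay, at which 3 of the 3 values shown sit). Compound 4 `OCC(CO)OCn1cnc2cc(Cl)c(Cl)cc21` differs from compound 1 in one place: hydrogen in place of chloro on an aromatic carbon. Going by the values given here, no measured step involves this change, and all three known values are limits, so neither direction nor size can be read from them. The estimate for compound 4 is 100000 nM, with a range from 30000 nM to 300000 nM. This expected value means a step of a number no higher from compound 1 to compound 4 (the limit leaves the size open), most likely ending again as a limit.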

Compound 4, half-maximal inhibitory concentration: > 100000 nM
Compound 4 ended at the assay's limit (the forecaster's own chance of this, stated with the estimate: 85%); the middle value lies on the limit itself.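

Compound 4 also gives only a limit, so its steps from compound 1, compound 2 and compound 3 cannot be read: the limit of > 100000 nM in this assay, at which 4 of the 4 values shown sit. On these data alone, whether any change to the shared core gives readable inhibition in this assay stays open.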